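Pyridyl for phenyl on the piperidine carbon of compound 1

The source may report more compounds than this note shows. Statements on the series, on what has been measured and on what is new or still open speak of the compounds shown alone.

Among the measured compounds shown here, compound 1 `Cc1cccc(NC(=O)CN2CCC(c3ccccc3)CC2)c1` is the only member of the series with a number in a functional assay on cells for agonist activity at D(4) dopamine receptor (Homo sapiens), read by TR-FRET and cAMP accumulation, with a stated time of 30 min (a lower number here means a smaller maximal response, a higher number a larger maximal response), where compound 1 reaches 32.9%; this is a partial maximal response in relation to the control. For the measured compounds named here, compound 2 `O=C(CN1CCN(c2ccccn2)CC1)Nc1cncnc1` was run in this assay as well and is recorded as "not active" (no number reported), without a figure, so no step can be taken from it. Compound 1 therefore stands alone as the reference point, and nothing in the data shows how changes at the saturated ring carbon move the maximal response.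

Compound 3 `Cc1ccc(C2CCN(CC(=O)Nc3cccc(C)c3)CC2)nc1` differs from compound 1 in one place: 5-methylpyridin-2-yl in place of phenyl on a saturated ring carbon. The rest of the shared core, including the amide and the aryl group on its nitrogen, is unchanged.

Going by the values given here, with no measured step of this kind to lean on, the expectation for this assay is a step from compound 1 to compound 3 of a number 2.9 percentage points lower from compound 1 to compound 3 (within the scatter), that is, no clear movement beyond the usual scatter, though the single reference value leaves the direction open. On that basis compound 3 is estimated at 30%, with a range from 12% to 52%, and some chance that only inactivity is reported.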

Compound 3, largest response reached (Emax), in percent of the reference or control that the assay uses: "not active" (no number reported)
No number was reported for compound 3, so the estimate cannot be set against anything.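

Among the compounds shown here, compound 3 carries no number in this assay, so no step from compound 1 can be read. Nothing shown offers an explanation for this result.

The compounds shown leave open whether the ring nitrogen or the methyl of 5-methylpyridin-2-yl, taken alone, would change the maximal response of compound 1.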